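Thiourea to cyanoguanidine on the pyridazinone-chain series

The source may report more compounds than this note shows. Statements on the series, on what has been measured and on what is new or still open speak of the compounds shown alone.

Measured so far:
Compound 1, `CC/N=C(\S)NCCCCCn1nc(-c2ccccc2)ccc1=O`: in a functional assay on the whole organism (stomach) with Rattus norvegicus as the target (on this read-out higher numbers stand for an effect only at larger amounts of compound and lower numbers for an effect already at smaller amounts), compound 1 gives 51.8 mg/kg.
Compound 2, `CC(C)(C)/N=C(\S)NCCCCn1nc(-c2ccccc2)ccc1=O`: in this assay compound 2 reaches only a limit, > 100 mg/kg, and not a number.

Among the measured compounds shown here, compound 1 carries the only number in this assay; the other value shown is a limit, so compound 1 has no measured neighbour to rank against. For the measured compounds named here, the one measured step, an at least 1.9-fold higher number from compound 1 to compound 2 (0.28 log units; that floor lies within the scatter), changes the group on the saturated chain carbon four bonds from the aromatic nitrogen and ends at the limit described by the limit of > 100 mg/kg in this assay, at which 1 of the 2 values shown sits, so it gives a direction but no size.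

Compound 3, `CCC/N=C(/NC#N)NCCCCCn1nc(-c2ccccc2)ccc1=O`, differs from compound 1 by a group of 8 heavy atoms (5 carbon, 3 nitrogen; no ring) in place of a group of 5 heavy atoms (3 carbon, 1 nitrogen, 1 sulfur; no ring), on an amine nitrogen. Going by the values given here, this change sits on the amine nitrogen, not on the chain carbon touched by the step from compound 1 to compound 2, so no measured step bears directly on it. With nothing to anchor the size or direction, the step from compound 1 to compound 3 is expected to be small, a 1.0-fold lower number from compound 1 to compound 3 (0.02 log units; within the scatter), well within the usual scatter. Compound 3 is therefore estimated at 50 mg/kg, with a range from 15 mg/kg to 160 mg/kg, and the chance of only a limit being reported is not negligible.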

Compound 3, dose for half-maximal effect: > 100 mg/kg
Compound 3: no number, only a limit (the forecaster's own chance of this, stated with the estimate: 30%); middle value at least 2.0-fold (0.30 log units) away from the limit.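

The amine nitrogen now has a reading of its own: in this assay, putting the cyanoguanidine group of 8 heavy atoms in place of the sulfur-bearing group of 5 heavy atoms gives an at least 1.9-fold higher number from compound 1 to compound 3 (0.28 log units; that floor lies within the scatter). Compound 3 gives only a limit, > 100 mg/kg, so this step has no size, and its floor alone does not clear the scatter. Compound 1 remains the only compound with a number, and the changes on the saturated chain carbon and on the amine nitrogen both end at the same limit: the limit of > 100 mg/kg in this assay, at which 2 of the 3 values shown sit.

The group change on the amine nitrogen swaps sulfur for the cyanoguanidine nitrogen and also carries a propyl group where compound 1 has an ethyl group, so the compounds shown cannot separate these two differences. From the compounds shown here alone, a cyanoguanidine with an ethyl group, or a urea with the same ethyl group, on the same pentyl chain would address that, while how far compound 3 lies beyond its limit stays open.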